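A few compounds are considered here, and "the series" means these few. Any claim that something is new, unique, unknown or untested is made for them only; others in the source may bear on it.

Of the compounds shown here, two sharing one core have been tested in a functional assay on LOX IMVI cells (Homo sapiens) for inhibition, read by sulforhodamine B assay, with a stated time of 48 h; a lower number here means a stronger inhibitor of growth, a higher number a weaker inhibitor of growth. There, compound 1 `CN1CCN(CCCOc2cccc3nc(Nc4ccc(Cl)c(C(F)(F)F)c4)ccc23)CC1` gives 1560 nM and compound 2 `CN1CCN(CCCOc2cccc3nc(Nc4ccc(Cl)c(F)c4)ccc23)CC1` gives 1640 nM. These numbers lie within the scatter of each other, so compound 2 stands level with compound 1 and neither can be ranked above the other.

The next compound, compound 3 `CC(C)c1ccc(Nc2ccc3c(OCCCN4CCN(C)CC4)cccc3n2)cc1`, keeps the shared core and changes one group: 4-isopropylphenyl in place of 4-chloro-3-fluorophenyl on a nitrogen on an aromatic ring. In words, 4-isopropylphenyl stands in place of 4-chloro-3-fluorophenyl on a nitrogen on an aromatic ring.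

Going by the values given here, only one measured step bears on this change: a 1.1-fold higher number from compound 1 to compound 2 (0.02 log units; within the scatter). It was a swap of fluoro in place of trifluoromethyl on an aromatic carbon, and it stayed within the scatter. It is a smaller edit than the one now made, since the chloro group stayed in place across it. Among the compounds with values here, no measured compound here carries the 4-isopropylphenyl group, so the evidence is thin. On the strength of that single flat step, no shift beyond the scatter is expected, though the range is kept wide.

The estimate for compound 3 is 1700 nM, with an expected range from 800 nM to 3600 nM. The expected change is a 1.0-fold higher number from compound 2 to compound 3 (0.02 log units; within the scatter).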

Compound 3, concentration for 50% growth inhibition: 1860 nM
For compound 3 the middle estimate is 1.1-fold (0.04 log units) below the measured one; low and high end bracket the measured number.
By their numbers in this assay, from the lowest: compounds 1, 2 and 3 (each within the scatter of the next).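

In this assay, the change on the nitrogen on an aromatic ring is far larger than the earlier swap, yet it gives a 1.1-fold higher number from compound 2 to compound 3 (0.05 log units; within the scatter), and the exchange of 4-chloro-3-(trifluoromethyl)phenyl for 4-isopropylphenyl gives a 1.2-fold higher number from compound 1 to compound 3 (0.08 log units; within the scatter). Going by these compounds alone, the earlier pair showed only that one group on the aromatic ring could be exchanged while the chloro group stayed in place; compound 3 shows that a phenyl group carrying no fluorine or chlorine at all, with only carbon in the entering 4-isopropylphenyl group, also stands level with both halogen-bearing compounds. Nothing measured here accounts for this flat result.

On these data alone, whether the level holds for a phenyl group carrying a carboxylic acid, an amine or an amide, or for a plain alkyl group in place of the phenyl ring on that nitrogen, stays open. As far as these compounds go, all three compounds also keep the rest of the shared core unchanged, so the effect of a longer chain or of a morpholine in place of the methylpiperazine remains unknown.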